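A few compounds are considered here, and "the series" means these few. Any claim that something is new, unique, unknown or untested is made for them only; others in the source may bear on it.

Measured compounds and their values:

- compound 1, `CNC(=O)/C=C/c1ccncc1-c1ccc2ccccc2c1`, gives 101% in an assay on a protein complex for inhibition of CDK8/Cyclin C (Homo sapiens), with a stated time of 1 h, tested at 10 uM; on this read-out higher numbers stand for more inhibition at the one concentration tested (going by the name of the read-out) and lower numbers for less inhibition
- compound 2, `O=C(/C=C/c1ccncc1-c1ccc2ccccc2c1)NC1CC1`, gives 102% in this assay
- compound 3, `O=C(O)/C=C/c1ccncc1-c1ccc2ccccc2c1`, gives 102% in this assay

Compound 3 stands level with compound 2 at the digits printed, and together they are the highest of the three numbers; the step of a number 1 percentage points higher from compound 1 to compound 3 (within the scatter) and the step of no change at the digits printed from compound 2 to compound 3 (within the scatter) both lie within the scatter, so the three compounds are not separated by this assay at all, and their numbers are level with one another at the concentration tested.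

Compound 4, `O=C(/C=C/c1ccncc1-c1ccc2ccccc2c1)N1CCOCC1`, differs from compound 3 in one place: morpholin-4-yl in place of hydroxy on a carbonyl carbon Cut one bond further out, the change reads carboxy to (morpholin-4-yl)carbonyl.

Among the compounds with values here, two measured steps bear on this change, since both swap a nitrogen-bearing group for hydroxy on the same carbonyl carbon: a number 1 percentage points higher from compound 1 to compound 3 (within the scatter) and no change at the digits printed from compound 2 to compound 3 (within the scatter). Both are within the scatter. The change to compound 4 runs the other way, from hydroxy to a nitrogen-bearing group, and morpholin-4-yl is not among the groups already measured, but nothing in these numbers points to a step beyond the scatter. Since all three measured numbers are level with one another and already high, there is also little room for an upward move. The expected step is therefore a number 4 percentage points lower from compound 3 to compound 4 (within the scatter), that is, none beyond the scatter. Compound 4 is estimated to give 98% in this assay, with an expected range from 82% to 105%.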

Compound 4, a percentage reported as inhibition, at one concentration (the size of the read-out at that concentration, not a potency): 99%
Compound 4: the middle estimate sits 1 percentage points below what was measured, and the stated range covers the measured number.
By their numbers in this assay, from the lowest: compounds 4, 1, 2 and 3 (each within the scatter of the next).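

In this assay, within the data shown here, the carbonyl carbon also accepts a much larger group than the earlier compounds showed: morpholin-4-yl, with its six-membered non-aromatic ring and no hydrogen-bond donor, stays within the scatter of hydroxy (a number 3 percentage points lower from compound 3 to compound 4 (within the scatter)). The same holds against the two smaller nitrogen groups, cyclopropylamino (a number 3 percentage points lower from compound 2 to compound 4 (within the scatter)) and methylamino (a number 2 percentage points lower from compound 1 to compound 4 (within the scatter)), so all four compounds remain unseparated at this one concentration. No supporting evidence is available on why the number holds across these groups.

Still open, as far as these compounds go, is whether a piperazin-1-yl ring or a long alkyl chain on this carbonyl carbon would lower the number. From the compounds shown here alone, a single concentration also gives no potency, so any differences between these four compounds at lower concentrations remain unknown.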